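Working notes on the step from compound 2 to compound 4

The source may hold more compounds than are shown below. What is called first, only, known or untested is meant among the compounds shown, and "the series" means these compounds.

Three compounds of the series carry numbers in a functional assay on Jurkat cells (Homo sapiens) for cytotoxicity, read by MTT assay, with a stated time of 24 h; a lower number here means that less compound is needed, a higher number that more compound is needed for the effect. Compound 1 `CCOC(=O)c1cc([Se]c2ccccc2)c2cc(Br)ccc2n1` gives 20800 nM. Compound 3 `COc1ccc2nc(-c3c(C)cccc3C)cc([Se]c3ccccc3)c2c1` gives 26900 nM. Compound 2 `CCOC(=O)c1cc(C#Cc2ccc(N)cc2)c2cc(OC)ccc2n1` gives 61000 nM, the highest of the three numbers; its nearest neighbour on the scale is compound 3, with a gap beyond the scatter, and the widest gap is to compound 1, also beyond the scatter. Going by the values given here, no two of these three compounds differ in a single place, so no step between measured compounds can be read off.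

Compound 4 `CCOC(=O)c1cc(C#Cc2ccccc2[N+](=O)[O-])c2cc(OC)ccc2n1` is not yet measured in this assay. The change from compound 2 to compound 4 is 2-nitrophenyl in place of 4-aminophenyl on a triple-bonded carbon. The shared core and everything else stay as in compound 2. Among the compounds with values here, no measured pair carries this same change, and compounds 1 and 3 differ from compound 2 on the triple-bonded carbon and elsewhere at once, so nothing measured fixes the size of this step. The expected step from compound 2 to compound 4 is a 1.4-fold lower number from compound 2 to compound 4 (0.13 log units; within the scatter), that is, no shift beyond the scatter, with wide uncertainty in either direction. Compound 4 is expected to give 45000 nM in this assay, within a range from 15000 nM to 150000 nM.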

Compound 4, half-maximal effective concentration: 54700 nM
Compound 4: middle estimate off by 1.2-fold (0.08 log units), on the low side, and the stated range covers the measured number.
By their numbers in this assay, from the lowest: compounds 1 and 3 (each within the scatter of the next); then compounds 4 and 2 (each within the scatter of the next).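

In this assay the series now has a step that can be read at this position: a 1.1-fold lower number from compound 2 to compound 4 (0.05 log units; within the scatter) for 2-nitrophenyl in place of 4-aminophenyl on a triple-bonded carbon. The earlier compounds shown here could not show this, and the step shows that this exchange, which removes the hydrogen-bond donor of 4-aminophenyl and brings in a larger group with a double bond outside aromatic rings, gives no shift beyond the scatter with the rest of compound 2 held constant. No measurement in hand bears on why the number holds across this change.

Going by these compounds alone, since only this one pair is available, the result cannot separate the change of substituent from the change in its place on the ring, and it cannot say whether a carboxylic acid or a longer chain on the same triple-bonded carbon would behave alike. Steps from compound 2 or compound 4 to compound 1 or compound 3 cannot be read, as those pairs differ in more than one place, so the contribution of the shared core and the ethyl ester also stays open.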